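Adding a fluoro group to compound 1

A few compounds are considered here, and "the series" means these few. Any claim that something is new, unique, unknown or untested is made for them only; others in the source may bear on it.

- compound 1 `O=C(Nc1ccc(F)cc1)c1cc(Cl)ccc1O`: 17000 nM
- compound 2 `O=C(Nc1ccc(OC(F)(F)F)cc1)c1cc(Cl)ccc1O`: 7300 nM
- compound 3 `N#Cc1ccc(NC(=O)c2cc(Cl)ccc2O)cc1`: 11000 nM

All three values come from an ADME assay on cells (Macrophage, Mus musculus) for cytotoxicity, read by resazurin assay, with a stated time of 3 days; a higher number here means a weaker inhibitor, a lower number a stronger inhibitor. Compound 1 stands at the high end of this small set, but only compound 2 is separated from it beyond the scatter: a 2.3-fold lower number from compound 1 to compound 2 (0.37 log units; beyond the scatter). By contrast, a 1.5-fold lower number from compound 1 to compound 3 (0.19 log units; within the scatter) stays within the scatter, as does a 1.5-fold higher number from compound 2 to compound 3 (0.18 log units; within the scatter).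

Compound 4 `O=C(Nc1ccc(F)cc1F)c1cc(Cl)ccc1O` carries one change from compound 1: fluoro in place of hydrogen on an aromatic carbon. This is fluoro in place of hydrogen on an aromatic carbon, ortho to a large group and meta to a fluoro group. Among the measured compounds shown here, no measured step makes this same change, so the other steps offer only indirect guidance. They replace a group rather than add one, and the largest is the modest step to compound 2 given above. A step beyond the scatter is therefore not expected, and any shift is expected to be small and towards a lower number. The expected change is a 1.3-fold lower number from compound 1 to compound 4 (0.12 log units; within the scatter). The estimated value for compound 4 is 13000 nM, with an expected range of 6500 nM to 26000 nM.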

Compound 4, half-maximal inhibitory concentration: 8500 nM
For compound 4 the middle estimate is 1.5-fold (0.18 log units) above the measured one; the range from low to high includes it.
By their numbers in this assay, from the lowest: compounds 2, 4, 3 and 1 (each within the scatter of the next, the first and the last beyond it).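

In this assay, adding fluoro in place of hydrogen, ortho to a large group and meta to a fluoro group, gives a 2.0-fold lower number from compound 1 to compound 4 (0.30 log units; within the scatter) and so does not separate the new compound from its parent. Among the compounds shown here, the earlier steps only exchanged one group for another at a single place, so this is the first reading of a second place on that ring, and the step there stays within the scatter. Nothing on hand bears on what lies behind this step.

On these data alone, whether an amine, a methoxy group or a carboxylic acid at this position would give a step beyond the scatter remains open. Also open, as far as these compounds go, is whether the same added fluoro would give a similar step on compound 2 or compound 3, which carry trifluoromethoxy and cyano groups.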